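Chloro to Nitro on a Shared Amide Core

The source may hold more compounds than are shown below. What is called first, only, known or untested is meant among the compounds shown, and "the series" means these compounds.

Measured compounds:
- Compound 1 `O=C(CSc1nc2ccc(NC(=O)c3ccc([N+](=O)[O-])cc3)cc2s1)NCc1ccccc1`: in a functional assay on MCF7 cells (Homo sapiens) for cytotoxicity, read by MTT assay, with a stated time of 48 h (on this read-out lower numbers stand for stronger inhibition and higher numbers for weaker inhibition), compound 1 reports > 100000 nM, which is a limit of the assay, not a number.
- Compound 2 `COc1ccc(CNC(=O)CSc2nc3ccc(NC(=O)c4ccc([N+](=O)[O-])cc4)cc3s2)cc1`: compound 2 also reports > 100000 nM, again a limit.
- Compound 3 `O=C(CSc1nc2ccc(NC(=O)c3ccc(Cl)cc3)cc2s1)NCc1ccc(Cl)cc1`: compound 3 gives 29300 nM.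

For the measured compounds named here, compound 3 therefore stands as the only compound with an actual number; the other two values are limits. The step that the two limits leave unreadable from compound 1 to compound 2 cannot be read, since both ends are limits, so it says nothing about size.

Compound 4 `O=C(CSc1nc2ccc(NC(=O)c3ccc([N+](=O)[O-])cc3)cc2s1)NCc1ccc(Cl)cc1` keeps the 4-chlorophenyl amide side of compound 3 but carries the change (nitro in place of chloro on an aromatic carbon), turning the (4-chlorophenyl)carbonyl into a (4-nitrophenyl)carbonyl. Going by the values given here, no measured step isolates this exact change. What the data show is that both compounds carrying a (4-nitrophenyl)carbonyl sit at the limit of > 100000 nM in this assay, at which 2 of the 3 values shown sit, while compound 3 without it gives a number. Compound 4 is therefore expected to be weaker than compound 3 by a 3.4-fold higher number from compound 3 to compound 4 (0.53 log units; beyond the scatter), most likely reaching the limit again. The estimate for compound 4 is 100000 nM, with a range from 40000 nM to 300000 nM.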

Compound 4, half-maximal inhibitory concentration: > 100000 nM
Compound 4: only a limit was reported; the forecaster's own chance of this, stated with the estimate: 60%; the middle value sits exactly at the limit.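

Changing chloro to nitro on this ring now has a direct reading in this assay: the result is an at least 3.4-fold higher number from compound 3 to compound 4 (0.53 log units; beyond the scatter). As far as these compounds go, the value of compound 4 is a limit, not a number, so the full size of this step stays unknown. Compound 1, compound 2 and compound 4 all carry the (4-nitrophenyl)carbonyl, and the steps among them cannot be read, as both ends of each are limits, so hydrogen, methoxy and chloro on the other ring cannot be ranked with this group in place: the limit of > 100000 nM in this assay, at which 3 of the 4 values shown sit.

The compounds shown leave open how an amine or a carboxylic acid in place of chloro on this ring would read. They also leave open whether chloro here would still give a number with hydrogen or methoxy on the other ring.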